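Chloromethyl ketone in place of diazoketone on the dodecyl chain

The source may hold more compounds than are shown below. What is called first, only, known or untested is meant among the compounds shown, and "the series" means these compounds.

Three compounds of the series have results in a functional assay on MOLT-3 cells (Homo sapiens); a higher number here means a weaker inhibitor, a lower number a stronger inhibitor. Going by the values given here, compound 2 `CCCCCCCCCCCCSC[C@H](NC(C)=O)C(=O)C=[N+]=[N-]` gives 22900 nM, the only number in this assay that is not a limit. Compound 1 `CC(=O)N[C@@H](CSC/C=C(\C)CCC=C(C)C)C(=O)C=[N+]=[N-]` reaches only the limit > 100000 nM in this assay. Compound 3 `CC(=O)N[C@@H](CSC/C=C(\C)CCC=C(C)C)C(=O)CCl` likewise sits at the limit > 100000 nM. The step that the two limits leave unreadable from compound 1 to compound 3 stays unreadable because the limit of > 100000 nM in this assay, at which 2 of the 3 values shown sit, hides where either compound really stands.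

Compound 4 `CCCCCCCCCCCCSC[C@H](NC(C)=O)C(=O)CCl` is not yet measured. It differs from compound 2 by a group of 2 heavy atoms (1 carbon, 1 chlorine; no ring) in place of a group of 3 heavy atoms (1 carbon, 2 nitrogen; no ring), on a carbonyl carbon; the group that leaves carries two double bonds outside aromatic rings and no hydrogen-bond donors or acceptors, and the chloromethyl that enters carries none either. Among the compounds with values here, the only measured step of the same kind is the one between compound 1 and compound 3, and its size cannot be read, so no measured pair gives a usable size for the change. On that basis the expected step of a 1.1-fold higher number from compound 2 to compound 4 (0.04 log units; within the scatter) in this assay is none beyond the scatter, with a wide range to cover the lack of guidance. Compound 4 is therefore expected to give about 25000 nM in this assay, between 6000 nM and 100000 nM.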

Compound 4, half-maximal inhibitory concentration: 2300 nM
Compound 4: middle estimate off by 11-fold (1.04 log units), on the high side; measured number outside the range, below it.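

In this assay the exchange of the diazoketone group for chloromethyl on the carbonyl carbon gives a 10-fold lower number from compound 2 to compound 4 (1.00 log units; beyond the scatter) on the dodecyl chain, so this position responds to the change by a measurable amount. Going by these compounds alone, this is the first readable size for the exchange and it lies beyond the scatter, so the group on the carbonyl carbon cannot be treated as interchangeable on this chain. The earlier pair with the other chain could not show this, as its step cannot be read because compound 1 and compound 3 both stand at a limit: the limit of > 100000 nM in this assay, at which 2 of the 4 values shown sit.

On these data alone, the size rests on a single pair, so whether the exchange carries over to the chain of compound 1 remains open, as does any general rule across chains. Also open, as far as these compounds go, is how other groups on the carbonyl carbon, such as bromomethyl or fluoromethyl, would compare with chloromethyl on the dodecyl chain, and how a longer chain would read with chloromethyl in place.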